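A Chlorine Removed From the Shared Core: Expected Cell Toxicity

The source may hold more compounds than are shown below. What is called first, only, known or untested is meant among the compounds shown, and "the series" means these compounds.

Four related compounds share the same core and a chloromethyl-bearing benzyl group. Compound 1 `ClCc1ccc(Cn2cnc3c(Cl)ncnc32)cc1` carries a single chloro group on the core; in a functional assay on SNB-75 cells (Homo sapiens) for cytotoxicity, read by sulforhodamine B assay, with a stated time of 48 h (on this read-out higher numbers stand for lower toxicity in this test and lower numbers for higher toxicity in this test), compound 1 has "not determined" (no result reported). Compound 2 `ClCc1ccccc1Cn1cnc2c(Cl)nc(Cl)nc21` carries two chloro groups on the core, and in this assay compound 2 likewise has "not determined" (no result reported). Compound 3 `Nc1nc(Cl)c2ncn(Cc3ccc(CCl)cc3)c2n1` carries an amino group together with one chloro group. In this assay compound 3 reached only the limit of the test, > 100000 nM, which is a limit and not a number. Compound 2 therefore stands without a single number of its own; of the other two results, one is a limit and one is an entry without a number, as the limit of > 100000 nM in this assay, at which 1 of the 3 values shown sits, summarises.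

Compound 4 `ClCc1ccccc1Cn1cnc2c(Cl)ncnc21` differs from compound 2 in one place: hydrogen in place of chloro on an aromatic carbon. Within the data shown here, no step between two measured compounds is available to say how large such a change runs in this assay, in either direction. The only measured result, that of compound 3, is the limit > 100000 nM, and compound 4 also lacks an amino group, so a reading beyond the limit seems most likely. Compound 4 is expected to give about 100000 nM in this assay, within a range from 30000 nM to 300000 nM.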

Compound 4, concentration lethal to 50% of the cells: 39800 nM
Estimate against measurement, compound 4: 2.5-fold (0.40 log units) above; the measured number falls inside the stated range.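

Compound 4 now has a number, but compound 2, which differs from it in one place, has no single number to set against it, so no step can be read between compound 2 and compound 4. The compounds shown leave open how far, and in which direction, replacing chloro with hydrogen between two ring nitrogen atoms shifts the result in this assay.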